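The source may hold more compounds than are shown below. What is called first, only, known or untested is meant among the compounds shown, and "the series" means these compounds.

Measured compounds in the series:

compound 1 — `O=C(CCCCC[C@H](NC(=O)c1ccc(Br)cc1)C(=O)Nc1ccc(-c2ccccc2)cc1)NO` — 197 nM
compound 2 — `CN(C)c1ccc(C(=O)N[C@@H](CCCCCC(=O)NO)C(=O)Nc2cccc3cccnc23)cc1` — 45 nM

Both were run in a functional assay on T47D cells (Homo sapiens) for antiproliferative activity; on this read-out higher numbers stand for weaker inhibition and lower numbers for stronger inhibition. On those two numbers compound 2 stands lowest; its nearest neighbour is compound 1, whose value lies beyond the scatter above it. Among the compounds with values here, compound 1 and compound 2 differ in more than one place, so no single step between them is assigned; their two values are simply what they are.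

The next compound, compound 3 `O=C(/C=C/c1ccccc1)N[C@@H](CCCCCC(=O)NO)C(=O)Nc1cccc2cccnc12`, keeps the whole frame of compound 2 and changes only the cap on the carbonyl: 2-phenylethenyl in place of 4-(dimethylamino)phenyl on a carbonyl carbon. Within the data shown here, no step between measured compounds isolates this kind of exchange, so there is nothing to scale it against. The expectation is a small step, within the scatter or slightly upward, from compound 2 to compound 3, estimated as a 1.4-fold higher number from compound 2 to compound 3 (0.16 log units; within the scatter). Compound 3 is accordingly expected to give about 65 nM, with a range from 22 nM to 190 nM.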

Compound 3, half-maximal inhibitory concentration: 20 nM
Beside the measured number, compound 3's estimate is 3.3-fold (0.51 log units) above it; the whole stated range lies above it.
By their numbers in this assay, from the lowest: compound 3; then compound 2; then compound 1.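

In this assay, the cap on the carbonyl turns out to be a position that moves the number: with the rest of the frame held whole, 2-phenylethenyl in place of 4-(dimethylamino)phenyl gives a 2.3-fold lower number from compound 2 to compound 3 (0.35 log units; beyond the scatter). This is the only single-place change shown in the series, and the step is modest but beyond the scatter. The exchange removes the dimethylamino nitrogen and adds a double bond outside aromatic rings, and no supporting measurement explains the lower number.

Going by these compounds, it remains open which part of the exchange carries the step: a 2-phenylethyl cap, without the double bond, or a 4-(dimethylamino)-substituted 2-phenylethenyl cap would separate the two parts. Also open, on these data alone, is whether the same exchange gives a comparable step on the core of compound 1.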